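Aryl swap at the thiazole of a carboxymethyl series

A few compounds are considered here, and "the series" means these few. Any claim that something is new, unique, unknown or untested is made for them only; others in the source may bear on it.

Measured compounds and their largest response in an in vitro functional assay on HEK285-7 cells for antagonist activity at prostaglandin D2 receptor 2 (Homo sapiens), read by BRET and beta-arrestin recruitment; a higher number here means a larger maximal response, a lower number a smaller maximal response:
compound 1, `O=C(O)Cc1sc(C(c2ccc(F)cc2)c2ccc(F)cc2)nc1-c1cc(F)cc(F)c1`, gives 80%;
compound 2, `O=C(O)Cc1sc(C(c2ccc(F)cc2)c2ccc(F)cc2)nc1-c1cccc(F)c1`, gives 80%;
compound 3, `O=C(O)Cc1sc(C(c2ccc(F)cc2)c2ccc(F)cc2)nc1-c1ccnc(Cl)c1`, gives 80%.

All three share the core of compound 1 and differ only in the aromatic group on the five-membered ring. Compound 3 stands level with compounds 1 and 2 in this assay; the step of no change at the digits printed from compound 1 to compound 3 (within the scatter) and the step of no change at the digits printed from compound 2 to compound 3 (within the scatter) are both within the scatter, as is the step of no change at the digits printed from compound 1 to compound 2 (within the scatter).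

Compound 4, `Cc1cc(-c2nc(C(c3ccc(F)cc3)c3ccc(F)cc3)sc2CC(=O)O)cnc1N`, has not yet been measured. Relative to compound 3 the change is 6-amino-5-methylpyridin-3-yl in place of 2-chloropyridin-4-yl on an aromatic carbon. The three measured steps all exchange the aromatic group at the same place and none moved the largest response beyond the scatter, so on these numbers an exchange there is expected to leave the maximal response where it is, even with an aminopyridine now in place of a chloropyridine. The estimated step of no change at the digits printed from compound 3 to compound 4 (within the scatter) is therefore expected to fall within the scatter. For compound 4 the expected value in this assay is 80%, with a range from 65% to 95%.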

Compound 4, largest response reached (reported as efficacy), in percent of the reference or control that the assay uses: 80%
Beside the measured number, compound 4's estimate shows no gap at the digits printed, and the stated range covers the measured number.
By their numbers in this assay, from the lowest: compounds 1, 2, 3 and 4 (each within the scatter of the next).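

In this assay the exchange at this aromatic carbon of the five-membered aromatic ring gives no change at the digits printed from compound 3 to compound 4 (within the scatter), and here 6-amino-5-methylpyridin-3-yl, unlike 2-chloropyridin-4-yl, brings a hydrogen-bond donor and no chlorine. The comparison with the two phenyl-bearing compounds reads the same, with no change at the digits printed from compound 2 to compound 4 (within the scatter) and no change at the digits printed from compound 1 to compound 4 (within the scatter), so all four aromatic groups at this position, now including an amino- and methyl-substituted pyridine, stand level in the largest response. No measurement shown here accounts for this level response or links it to any feature of the groups.

All four values being level, the compounds shown identify no group at this position that separates one maximal response from another, and a piperidine, a carboxylic acid or a longer alkyl chain there remains an open case. Equally open, on these data alone, is what an amide in place of the carboxylic acid of the carboxymethyl group would do to the response in this assay, since that group and the rest of the shared core stay the same throughout.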